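The source may report more compounds than this note shows. Statements on the series, on what has been measured and on what is new or still open speak of the compounds shown alone.

Values in a functional assay on HepG2 cells (Homo sapiens) for cytotoxicity, read by MTT assay, with a stated time of 48 h (a lower number here means a stronger inhibitor, a higher number a weaker inhibitor), so far
compound 1 `CC1=NN(C(=O)CCl)C(c2cc(Br)ccc2O)C1` gives 16300 nM
compound 2 `CC1=NN(S(=O)(=O)c2ccc(C)cc2)C(c2cc(Br)ccc2O)C1` gives 20800 nM
compound 3 `CC1=NN(S(=O)(=O)c2ccc([N+](=O)[O-])cc2)C(c2cc(Br)cc(Br)c2O)C1` gives "not active" (no number reported)

Compound 3 has no single number on this scale, since it was reported only as "not active" (no number reported) in the test. Compound 4 `CC1=NN(S(=O)(=O)c2ccc(C)cc2)C(c2cc(Br)cc(Br)c2O)C1` has not yet been measured. The change methyl in place of nitro on an aromatic carbon puts methyl in place of nitro on an aromatic carbon. With no number for compound 3, no size can be put on this step, but the expected direction is toward a measurable value. The closest guide is compound 2, which also carries 4-methylphenyl and gives 20800 nM in this assay as its reading. For compound 4 the expected value is 22000 nM, with an estimated range from 9000 nM to 60000 nM as the likely span.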

Compound 4, half-maximal inhibitory concentration: "not active" (no number reported)
Compound 4 has no reported number here; no gap can be computed for the estimate.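

In this assay, going by these compounds alone, compound 3 gives "not active" (no number reported) and compound 4 gives "not active" (no number reported) as well, so no step between them can be read. Nothing measured here explains these results. From the compounds shown here alone, how 4-nitrophenyl and 4-methylphenyl compare on this shared core stays open.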